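This account rests on a few compounds, and the source may have more. Where it says the series, first, only, none or still open, it means among the compounds named here.

Compound 1 `Cc1cc(O)c(C2=NN(c3ccc(S(N)(=O)=O)cc3)C(c3ccccc3O)C2)cc1Cl`: 100000 nM in a functional assay on CCRF-CEM cells (Homo sapiens) for antiproliferative activity, with a stated time of 48 h; a higher number here means a weaker inhibitor of growth, a lower number a stronger inhibitor of growth.
Compound 2 `Cc1cc(O)c(C2=NN(c3ccc(S(N)(=O)=O)cc3)C(c3ccccc3Cl)C2)cc1Cl`: 100000 nM in this assay.

Compound 2 stands level with compound 1 in this assay; the step of no change at the digits printed from compound 1 to compound 2 (within the scatter) is within the scatter. Compound 3 `Cc1cc(O)c(C2=NN(c3ccc(S(N)(=O)=O)cc3)C(/C=C/c3ccccc3)C2)cc1Cl` differs from compound 2 by 2-phenylethenyl in place of 2-chlorophenyl on a saturated ring carbon. Going by the values given here, no measured step covers this change; the only step, no change at the digits printed from compound 1 to compound 2 (within the scatter), left the value unchanged, so the numbers give no direction for it. Compound 3 is therefore expected to stay level with compound 2, a step of no change at the digits printed from compound 2 to compound 3 (within the scatter). Compound 3 is estimated at 100000 nM, range 30000 nM to 100000 nM.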

Compound 3, concentration for total growth inhibition: 50000 nM
The estimate for compound 3 lay 2.0-fold (0.30 log units) above the measured number; measured number inside the range.
By their numbers in this assay, from the lowest: compounds 3, 1 and 2 (each within the scatter of the next).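

At the saturated ring carbon, 2-phenylethenyl in place of 2-chlorophenyl gives a 2.0-fold lower number from compound 2 to compound 3 (0.30 log units; within the scatter) in this assay, and 2-phenylethenyl in place of 2-hydroxyphenyl gives a 2.0-fold lower number from compound 1 to compound 3 (0.30 log units; within the scatter). The three groups at this carbon, one of them with a double bond outside aromatic rings, therefore cannot be told apart in this read-out. No evidence bears on this result.

All three groups carry a six-membered aromatic carbon ring. As far as these compounds go, whether an amine, a carboxylic acid or a saturated alkyl chain at this carbon would move the number beyond the scatter stays open.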